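This account rests on a few compounds, and the source may have more. Where it says the series, first, only, none or still open, it means among the compounds named here.

Measured so far in a functional assay, with a stated time of 30 min; on this read-out lower numbers stand for stronger inhibition and higher numbers for weaker inhibition:
- compound 1, `CCCCc1oc2ccc(/N=C/c3ccc(C#N)cc3)cc2c1C(=O)c1ccc(OC)cc1`: compound 1 gives 27.2 ug/mL
- compound 2, `CCCCc1oc2ccc(/N=C/c3ccc(F)cc3)cc2c1C(=O)c1ccc(OC)cc1`: compound 2 gives 100 ug/mL
- compound 3, `CCCCc1oc2ccc(/N=C/c3ccccc3)cc2c1C(=O)c1ccc(OC)cc1`: compound 3 gives 34.2 ug/mL

Of the three numbers in this assay, compound 3 stands second highest. Its nearer neighbour is reached by a 1.3-fold higher number from compound 1 to compound 3 (0.10 log units; within the scatter), which stays within the scatter; its further neighbour by a 2.9-fold lower number from compound 2 to compound 3 (0.47 log units; beyond the scatter), which lies beyond it.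

Compound 4, `CCCCc1oc2ccc(/N=C/c3ccc(Cl)cc3Cl)cc2c1C(=O)c1ccc(OC)cc1`, differs from compound 3 by 2,4-dichlorophenyl in place of phenyl on a carbon with a double bond to nitrogen. For the measured compounds named here, the steps that bear on this change are those on the same aromatic ring: a 2.9-fold lower number from compound 2 to compound 3 (0.47 log units; beyond the scatter) and a 3.7-fold higher number from compound 1 to compound 2 (0.57 log units; beyond the scatter), both modest and beyond the scatter, with a 1.3-fold higher number from compound 1 to compound 3 (0.10 log units; within the scatter) within it. The only measured move from hydrogen to a halogen on that ring, from compound 3 to compound 2, ran to a higher number; two chlorines have not been tried, so the size is uncertain. A modest rise in this assay is expected for compound 4, namely a 1.6-fold higher number from compound 3 to compound 4 (0.21 log units; within the scatter). Compound 4 is estimated at 55 ug/mL, with a range from 22 ug/mL to 130 ug/mL.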

Compound 4, half-maximal inhibitory concentration: 2.44 ug/mL
Beside the measured number, compound 4's estimate is 23-fold (1.35 log units) above it; the whole stated range lies above it.
By their numbers in this assay, from the lowest: compound 4; then compounds 1 and 3 (each within the scatter of the next); then compound 2.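

In this assay, for the compounds shown here, this position can move the number much further than the single ring changes suggested: 2,4-dichlorophenyl in place of phenyl gives a 14-fold lower number from compound 3 to compound 4 (1.15 log units; beyond the scatter) and the same group also separates from the other two ring variants, with a 41-fold lower number from compound 2 to compound 4 (1.61 log units; beyond the scatter) and an 11-fold lower number from compound 1 to compound 4 (1.05 log units; beyond the scatter) in the same direction. Halogen on this ring does not act in one direction across the series, as compound 2 goes against any rule that halogen lowers the number. Nothing at hand explains the size of this drop.

Compound 4 brings two chlorines at once, so the share of each in the step stays unresolved. On these data alone, whether a single chlorine, a methoxy group or an amine on this ring would give a step of similar size also remains open.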